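Trifluoromethyl to chloro on the urea aryl ring

A few compounds are considered here, and "the series" means these few. Any claim that something is new, unique, unknown or untested is made for them only; others in the source may bear on it.

Measured so far in a functional assay on SNB-75 cells (Homo sapiens) for inhibition, read by sulforhodamine B assay, with a stated time of 48 h, tested at 0.01 uM; a lower number here means a stronger effect, a higher number a weaker effect of the compound at the concentration tested:
compound 1 `O=C(Nc1cccc(-n2cc(-c3ccncc3)c(-c3cc(O)cc(Cl)c3)n2)c1)Nc1ccc(Cl)c(C(F)(F)F)c1` gives 53%
compound 2 `O=C(Nc1cccc(-n2cc(-c3ccncc3)c(-c3cc(O)cc(Cl)c3)n2)c1)Nc1ccc(Cl)c(Cl)c1` gives 94%
compound 3 `COc1cc(Cl)cc(-c2nn(-c3cccc(NC(=O)Nc4ccc(Cl)c(C(F)(F)F)c4)c3)cc2-c2ccncc2)c1` gives 57%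

Compound 3 stands second highest of the three numbers in this assay; its nearest neighbour is compound 1, and that gap, a number 4 percentage points higher from compound 1 to compound 3 (within the scatter), lies within the scatter, while compound 2 is the furthest from it, beyond the scatter.

Compound 4 `COc1cc(Cl)cc(-c2nn(-c3cccc(NC(=O)Nc4ccc(Cl)c(Cl)c4)c3)cc2-c2ccncc2)c1` is not yet measured. It differs from compound 3 in one place: chloro in place of trifluoromethyl on an aromatic carbon.

Among the compounds with values here, one measured step bears directly on this change: a number 41 percentage points higher from compound 1 to compound 2 (beyond the scatter), the same exchange of trifluoromethyl for chloro on a scaffold that differs from compound 3 only in the methyl on the oxygen, a difference that itself moved the number only within the scatter. A step of similar size and direction is therefore expected here, a number 35 percentage points higher from compound 3 to compound 4 (beyond the scatter), bounded by the ceiling of the read-out. Compound 4 is expected to give about 92% in this assay, within 72% to 105%.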

Compound 4, a percentage reported as activity, at one concentration (the size of the read-out at that concentration, not a potency): 88%
Beside the measured number, compound 4's estimate is 4 percentage points above it, within the range that was stated.
By their numbers in this assay, from the lowest: compounds 1 and 3 (each within the scatter of the next); then compounds 4 and 2 (each within the scatter of the next).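

In this assay, the exchange of trifluoromethyl for chloro on the urea aryl ring now has a reading on a second core, with the methyl on the oxygen in place: a number 31 percentage points higher from compound 3 to compound 4 (beyond the scatter). The size of the step holds across the two cores: the same change on two cores in this assay, a number 41 percentage points higher (beyond the scatter) from compound 1 to compound 2 and a number 31 percentage points higher (beyond the scatter) from compound 3 to compound 4, 10 percentage points apart, within the scatter of two such steps Methyl in place of hydrogen on the oxygen, earlier read only with trifluoromethyl present, also stays within the scatter with chloro present, a number 6 percentage points lower from compound 2 to compound 4 (within the scatter), so the four compounds show no sign that the two changes depend on each other: the same change on two cores in this assay, a number 4 percentage points higher (within the scatter) from compound 1 to compound 3 and a number 6 percentage points lower (within the scatter) from compound 2 to compound 4, 10 percentage points apart, within the scatter of two such steps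

Only trifluoromethyl and chloro are shown at this position, so whether bromo, methyl or methoxy there would keep the stronger effect remains open. As far as these compounds go, on the oxygen, a longer chain such as ethyl is also open, and a single-concentration read-out gives no potency for any of the four compounds.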